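Swapping the amine link for an ether on the core

This account rests on a few compounds, and the source may have more. Where it says the series, first, only, none or still open, it means among the compounds named here.

Compound 3 `CC1(C)CCC(CN2CCN(c3ccc(C(=O)NS(=O)(=O)c4ccc(NC5CCOC5)c([N+](=O)[O-])c4)c(Oc4cnc5[nH]ccc5c4)c3)CC2)=C(c2ccc(C(F)(F)F)cc2)C1` gives 1.9 nM in an assay on isolated protein for displacement of a labelled ligand from Apoptosis regulator Bcl-2 (Homo sapiens), with a stated time of 15 min (a higher number here means a weaker inhibitor, a lower number a stronger inhibitor), the lowest of the three numbers shown. Compound 1 `CC(C)C(=O)N1CCC(CNc2ccc(S(=O)(=O)NC(=O)c3ccc(N4CCN(CC5=C(c6ccc(C(F)(F)F)cc6)CC(C)(C)CC5)CC4)cc3Oc3cnc4[nH]ccc4c3)cc2[N+](=O)[O-])CC1` gives 2.4 nM, and the step of a 1.3-fold lower number from compound 1 to compound 3 (0.10 log units; within the scatter) lies within the scatter. Compound 2 `CC1(C)CCC(CN2CCN(c3ccc(C(=O)NS(=O)(=O)c4ccc(NCC5CCOC5)c([N+](=O)[O-])c4)c(Oc4cnc5[nH]ccc5c4)c3)CC2)=C(c2ccc(C(F)(F)F)cc2)C1` gives 4.7 nM, and the step of a 2.5-fold lower number from compound 2 to compound 3 (0.39 log units; beyond the scatter) is the only one beyond the scatter. Compound 4 `CC1(C)CCC(CN2CCN(c3ccc(C(=O)NS(=O)(=O)c4ccc(OCC5CCSCC5)c([N+](=O)[O-])c4)c(Oc4cnc5[nH]ccc5c4)c3)CC2)=C(c2ccc(C(F)(F)F)cc2)C1` differs from compound 3 by a group of 8 heavy atoms (6 carbon, 1 oxygen, 1 sulfur; one six-membered non-aromatic ring with 1 hetero atom) in place of a group of 6 heavy atoms (4 carbon, 1 nitrogen, 1 oxygen; one five-membered non-aromatic ring with 1 hetero atom), on an aromatic carbon: a group of 8 heavy atoms (6 carbon, 1 oxygen, 1 sulfur; one six-membered non-aromatic ring with 1 hetero atom) in place of a group of 6 heavy atoms (4 carbon, 1 nitrogen, 1 oxygen; one five-membered non-aromatic ring with 1 hetero atom), ortho to a nitro group and para to a large group. The steps of a 2.0-fold higher number from compound 1 to compound 2 (0.29 log units; within the scatter) and a 2.5-fold lower number from compound 2 to compound 3 (0.39 log units; beyond the scatter) show that changing the ring on this position moves the number only modestly, and that a ring hung on an extra chain atom gave a somewhat higher number. Within the data shown here, no measured step removes the amine hydrogen. A modest rise is therefore expected for compound 4, a 2.6-fold higher number from compound 3 to compound 4 (0.42 log units; beyond the scatter), giving an estimate of 5 nM with a range from 1.5 nM to 15 nM.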

Compound 4, half-maximal inhibitory concentration: 1.65 nM
Compound 4: middle estimate off by 3.0-fold (0.48 log units), on the high side; the range from low to high includes it.
By their numbers in this assay, from the lowest: compounds 4, 3, 1 and 2 (each within the scatter of the next, the first and the last beyond it).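

Among these compounds, the group entering on this aromatic carbon has no hydrogen-bond donor, whereas all the earlier compounds keep the amine hydrogen, yet a 1.2-fold lower number from compound 3 to compound 4 (0.06 log units; within the scatter) in this assay is all that follows from the change. Among the compounds shown here, the amine hydrogen is therefore not required for a low number here, and a six-membered ring holding sulfur serves as well as the oxolan-3-yl ring, with a 2.8-fold lower number from compound 2 to compound 4 (0.45 log units; beyond the scatter) also placing the new group clear of the one compound already separated from compound 3. Nothing available explains why the number holds up.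

Link, chain and ring all change together in compound 4, so the share of each stays unknown. Also open, on these data alone, is how the same sulfur ring would behave on an amine link, and what a morpholine ring or a longer chain would do on the oxygen link.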